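The source may hold more compounds than are shown below. What is called first, only, known or untested is meant among the compounds shown, and "the series" means these compounds.

Compound 1 `CC(C)(C)c1ccc(CNCCCNS(=O)(=O)c2cc(C(F)(F)F)cc(C(F)(F)F)c2)cc1` is measured in a functional assay on PANC-1 cells (Homo sapiens) for inhibition, read by MTT assay, with a stated time of 72 h (on this read-out higher numbers stand for weaker inhibition of growth and lower numbers for stronger inhibition of growth), where compound 1 gives 2500 nM. Compound 2 `O=S(=O)(NCCCNCc1cccc2ccccc12)c1cc(C(F)(F)F)cc(C(F)(F)F)c1` gives 2700 nM in this assay, and the change of a 1.1-fold higher number from compound 1 to compound 2 (0.03 log units; within the scatter) means the two sit within the scatter of each other. Compound 3 `O=S(=O)(NCCCNCc1ccc(-c2ccccc2)cc1)c1cc(C(F)(F)F)cc(C(F)(F)F)c1` differs from compound 1 by phenyl in place of tert-butyl on an aromatic carbon. Among the measured compounds shown here, the only measured step, from compound 1 to compound 2, also changed the group on that end of the chain and stayed within the scatter, so for compound 3 no step beyond the scatter is expected, an estimated no change at the digits printed from compound 1 to compound 3 (within the scatter). Compound 3 is therefore expected to give about 2500 nM, between 1000 nM and 6000 nM.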

Compound 3, concentration for 50% growth inhibition: 2500 nM
For compound 3 middle estimate and measured number coincide at the digits printed; measured number inside the range.
By their numbers in this assay, from the lowest: compounds 1, 3 and 2 (each within the scatter of the next).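

Putting phenyl on this aromatic carbon in place of tert-butyl gives no change at the digits printed from compound 1 to compound 3 (within the scatter) in this assay and so shows that a ring of carbon and a branched group of four carbons can stand here without a step beyond the scatter. The earlier step replaced the whole aromatic end, whereas this one changes only the group on that ring. Nothing measured here accounts for this result. From the compounds shown here alone, it remains open whether a carboxylic acid or an amine on this aromatic carbon would give a similar number, and whether a longer chain in the core of compound 1 would.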